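The source may hold more compounds than are shown below. What is called first, only, known or untested is meant among the compounds shown, and "the series" means these compounds.

Compound 1 `O=C1N[C@H]2[C@H](CS[C@H]2CCCCCc2cn(Cc3ccccc3O)nn2)N1`, compound 2 `COc1ccccc1Cn1cc(CCCCC[C@@H]2SC[C@@H]3NC(=O)N[C@@H]32)nn1` and compound 3 `Nc1ccccc1Cn1cc(CCCCC[C@@H]2SC[C@@H]3NC(=O)N[C@@H]32)nn1` share one core and differ only at a single substituent. In an assay on isolated protein for inhibition of biotin--protein ligase (Homo sapiens), read by scintillation counting, with a stated time of 10 min (a higher number here means a weaker inhibitor, a lower number a stronger inhibitor), compound 1 gives > 16000 nM, which is a limit of the assay and not a number. Compound 2 likewise reaches only a limit, > 16000 nM. Compound 3 also shows only a limit, > 16000 nM. Hence a step that the two limits leave unreadable from compound 1 to compound 2, a step that the two limits leave unreadable from compound 1 to compound 3 and a step that the two limits leave unreadable from compound 2 to compound 3 cannot be sized, since every value sits at the limit of > 16000 nM in this assay, at which 3 of the 3 values shown sit. Compound 4 `O=C1N[C@H]2[C@H](CS[C@H]2CCCCCc2cn(Cc3cccc(C(F)(F)F)c3)nn2)N1` carries 3-(trifluoromethyl)phenyl in place of 2-methoxyphenyl on a saturated chain carbon bound to an aromatic nitrogen. Within the data shown here, no measured step bears readably on this change, so no direction can be drawn. Compound 4 is therefore expected to stay near the limit, at an estimated 20000 nM with a range of 5000 nM to 80000 nM. The expected step is a step that the limit leaves unreadable from compound 2 to compound 4.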

Compound 4, inhibition constant: > 16000 nM
Compound 4 ended at the assay's limit; the forecaster's own chance of this, stated with the estimate: 75%; the middle value lies beyond the limit too.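

The steps from compound 1, compound 2 and compound 3 to compound 4 cannot be read, as all four compounds end at the same limit: the limit of > 16000 nM in this assay, at which 4 of the 4 values shown sit.

The compounds shown leave open how far each lies beyond that limit and whether any substituent on the shared core gives a readable inhibition constant.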